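Chloro for ethoxycarbonyl on the glutaryl anilinopyrimidine

A few compounds are considered here, and "the series" means these few. Any claim that something is new, unique, unknown or untested is made for them only; others in the source may bear on it.

Compound 2 `CCOC(=O)c1ccc(Nc2cc(NC(=O)CCCC(=O)O)ncn2)cc1` stands lowest of the two numbers in an assay for inhibition of Receptor tyrosine-protein kinase erbB-3 variant L858R (Homo sapiens), read by mobility shift assay, with a stated time of 10 min (on this read-out higher numbers stand for weaker inhibition and lower numbers for stronger inhibition), at 69 nM; compound 1 `O=C(O)CCC(=O)Nc1cc(Nc2ccc(Cl)cc2)ncn1`, which carries chloro and a shorter chain, gives 825 nM, a gap beyond the scatter. Compound 3 `O=C(O)CCCC(=O)Nc1cc(Nc2ccc(Cl)cc2)ncn1` differs from compound 2 by chloro in place of ethoxycarbonyl on an aromatic carbon, the place being an aromatic carbon of a six-membered aromatic ring of carbon only, para to a large group. For the measured compounds named here, no single-point step is known, so the chloro-bearing compound 1 is the only guide. The step from compound 2 to compound 3 is expected to weaken inhibition, a 7.2-fold higher number from compound 2 to compound 3 (0.86 log units; beyond the scatter). Compound 3 is estimated at 500 nM, between 150 nM and 1600 nM.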

Compound 3, half-maximal inhibitory concentration: 1320 nM
Compound 3: middle estimate off by 2.6-fold (0.42 log units), on the low side; low and high end bracket the measured number.
By their numbers in this assay, from the lowest: compound 2; then compounds 1 and 3 (each within the scatter of the next).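

With the chain held, chloro in place of ethoxycarbonyl on the aromatic carbon gives a 19-fold higher number from compound 2 to compound 3 (1.28 log units; beyond the scatter), so the group at this position, para to a large group, matters greatly for the low number of compound 2. With chloro held, carboxymethyl in place of carboxy on the saturated chain gives a 1.6-fold higher number from compound 1 to compound 3 (0.20 log units; within the scatter), so no effect of this chain change can be read. Nothing measured here accounts for the large step.

From the compounds shown here alone, whether the whole ethoxycarbonyl group is needed stays open; a carboxylic acid or a methyl ester at this position would address that. Also open, going by these compounds, is how the shorter chain behaves with ethoxycarbonyl in place.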